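The source may hold more compounds than are shown below. What is called first, only, known or untested is meant among the compounds shown, and "the series" means these compounds.

Working notes on the series. In an ADME assay on BJ cells (Homo sapiens), read by MTT assay, with a stated time of 72 h (on this read-out lower numbers stand for stronger inhibition and higher numbers for weaker inhibition), compound 3 `CSc1ncnc2c1c(-c1cccs1)cn2[C@@H]1O[C@H](CO)[C@@H](O)[C@H]1O` gives 96900 nM, the second highest of the three numbers to hand. Compound 2 `CSc1ncnc2c1c(-c1ccoc1)cn2[C@@H]1O[C@H](CO)[C@@H](O)[C@H]1O` gives 98800 nM, within the scatter of compound 3. Compound 1 `COc1ncnc2c1c(-c1cc3ccccc3o1)cn2[C@@H]1O[C@H](CO)[C@@H](O)[C@H]1O` gives 22400 nM, a lower number and beyond the scatter of compound 3. However, compound 1 differs from compound 3 in more than one place, so it offers no direct guide here.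

The next compound is compound 4 `CSc1ncnc2c1c(-c1ccsc1)cn2[C@@H]1O[C@H](CO)[C@@H](O)[C@H]1O`, which has thiophen-3-yl in place of thiophen-2-yl on an aromatic carbon. The two have the same atoms, joined differently, and the place is unchanged: on an aromatic carbon of a five-membered aromatic ring with 1 nitrogen.

Within the data shown here, only one measured step bears on this change. It is a 1.0-fold lower number from compound 2 to compound 3 (0.01 log units; within the scatter), with thiophen-2-yl in place of furan-3-yl at that same place, and it stays within the scatter. Among the measured compounds shown here, no measured step yet covers a move between the two thiophene attachments themselves, so this is a single, indirect guide.

No step beyond the scatter is expected in this assay, and the expected step is a 1.0-fold lower number from compound 3 to compound 4 (0.01 log units; within the scatter). The estimate for compound 4 is 95000 nM, with an expected range of 55000 nM to 160000 nM.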

Compound 4, half-maximal inhibitory concentration: 95800 nM
Compound 4: the middle estimate sits 1.0-fold (0.00 log units) below what was measured, within the range that was stated.
By their numbers in this assay, from the lowest: compound 1; then compounds 4, 3 and 2 (each within the scatter of the next).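

In this assay, among these compounds, moving the thiophene attachment at this place, on an aromatic carbon of a five-membered aromatic ring with 1 nitrogen, gives a 1.0-fold lower number from compound 3 to compound 4 (0.00 log units; within the scatter), the first direct reading on thiophen-3-yl in place of thiophen-2-yl, and the two attachments cannot be told apart here. Keeping the attachment and exchanging the ring, thiophen-3-yl in place of furan-3-yl, gives a 1.0-fold lower number from compound 2 to compound 4 (0.01 log units; within the scatter), so across compound 2, compound 3 and compound 4 neither the attachment nor the choice between furan and thiophene moves the number beyond the scatter. Nothing further accompanies these results to account for this flat response.

As far as these compounds go, all three groups compared at this place are five-membered aromatic rings with 1 hetero atom, so it remains open whether an amine, a carboxylic acid or a longer alkyl chain there would also stay within the scatter. Compound 1 differs from these compounds in more than one place. It is therefore not compared with them here.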